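A few compounds are considered here, and "the series" means these few. Any claim that something is new, unique, unknown or untested is made for them only; others in the source may bear on it.

Of the compounds shown here, three that share one core have been measured in an assay on isolated protein (blood) for antagonist activity at C-C chemokine receptor type 4 (Homo sapiens), read by flow cytometry, with a stated time of 30 min; on this read-out lower numbers stand for tighter binding and higher numbers for weaker binding. Compound 1 `CC(=O)NCc1cccc(Cn2nc(NS(=O)(=O)c3ccc(Cl)s3)c3c(Cl)cccc32)c1` gives 6310 nM. Compound 2 `CC(=O)NCc1cccc(Cn2nc(NS(=O)(=O)c3ccc(Cl)s3)c3c(C(C)O)cccc32)c1` gives 501 nM. Within the data shown here, the single change on the core between these two carries a large step: a 13-fold lower number from compound 1 to compound 2 (1.10 log units; beyond the scatter). Compound 3 `COc1cccc2c1c(NS(=O)(=O)c1ccc(Cl)s1)nn2Cc1cccc(CNC(=O)C2CCCO2)c1` gives 794 nM, which stands second highest of the three numbers; its gap to compound 2 lies within the scatter, while its gap to compound 1 lies beyond it.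

Compound 4 `COc1cccc2c1c(NS(=O)(=O)c1ccc(Cl)s1)nn2Cc1cccc(CNC(=O)C(C)(C)N)c1` has not yet been measured. It differs from compound 3 only at the amide tail: 1-amino-1-methylethyl in place of oxolan-2-yl on a carbonyl carbon. Among the measured compounds shown here, no measured step touches this part of the molecule; the one step shown sits on an aromatic carbon of the core and therefore does not bear on this change. With nothing pointing in either direction, no step beyond the scatter is expected. For compound 4 the expected step is a 1.0-fold higher number from compound 3 to compound 4 (0.00 log units; within the scatter). Compound 4 is therefore expected to give about 800 nM, in a range from 250 nM to 2500 nM.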

Compound 4, dissociation constant: 141 nM
Beside the measured number, compound 4's estimate is 5.7-fold (0.75 log units) above it; measured number outside the range, below it.
By their numbers in this assay, from the lowest: compound 4; then compounds 2 and 3 (each within the scatter of the next); then compound 1.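

In this assay, the amide tail turns out to be a place where the read-out responds: 1-amino-1-methylethyl in place of oxolan-2-yl on the carbonyl carbon gives a 5.6-fold lower number from compound 3 to compound 4 (0.75 log units; beyond the scatter). Among these compounds, the only earlier step lay on an aromatic carbon of the core, so this is the first sign that the far end of the molecule matters as well. The entering group has no ring and carries a hydrogen-bond donor, but no measurement here ties the step to either difference.

Still open, going by these compounds, is whether the amine alone is enough, which a tail such as aminomethyl or a longer chain ending in an amine would test, and how a carboxylic acid in the same place would compare. On these data alone, it is also open whether the same tail change would give a similar step on the core of compound 2.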